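A few compounds are considered here, and "the series" means these few. Any claim that something is new, unique, unknown or untested is made for them only; others in the source may bear on it.

Compounds measured so far in a functional assay on K562 cells (Homo sapiens) for inhibition, read by sulforhodamine B assay, with a stated time of 48 h; a higher number here means a weaker inhibitor of growth, a lower number a stronger inhibitor of growth:
Compound 1 `CCOC(=O)c1nn(-c2ccccc2)c(-c2ccc(F)cc2)c1CNC(C)(C)C`: 75700 nM; 161000 nM (2 entries)
Compound 2 `CCOC(=O)c1nn(-c2ccc(Cl)cc2)c(-c2ccc(OC)cc2)c1CNC(C)(C)C`: 6100 nM; > 523000 nM (2 entries)
Compound 3 `CC(C)(C)NCc1c(C(=O)O)nn(-c2ccccc2)c1-c1ccc(F)cc1`: > 680000 nM

The two entries for compound 2 are one number and one limit of the assay, and they do not agree closely. Compound 3 has no measured number in this assay at all, only a limit of > 680000 nM as its reading. So its place is known only from that limit, and it gives no exact starting point.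

The next structure is compound 4 `Cc1ccc(-c2c(CNC(C)(C)C)c(C(=O)O)nn2-c2ccccc2)cc1` and the change is small: methyl in place of fluoro on an aromatic carbon with methyl in place of fluoro on an aromatic carbon, para to a large group. The rest of the molecule stays the same. No measured pair of these compounds shows what such a swap does. The expected result is therefore an at least 1.1-fold lower number from compound 3 to compound 4 (0.05 log units; that floor lies within the scatter) and no change beyond the scatter in either direction, with a fair chance that only a limit is reported. For compound 4 the estimated value is 600000 nM (expected range 150000 nM to 1000000 nM).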

Compound 4, concentration for 50% growth inhibition: > 688000 nM
Compound 4 gave a limit, no number (the forecaster's own chance of this, stated with the estimate: 70%); middle value at least 1.1-fold (0.05 log units) away from the limit.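

In this assay, compound 3 and compound 4 each gave only a limit of the assay and not a number, and no step can be read between them. The compounds shown leave open whether methyl in place of fluoro changes growth inhibition at all.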